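A few compounds are considered here, and "the series" means these few. Any claim that something is new, unique, unknown or untested is made for them only; others in the source may bear on it.

Measured compounds:
Compound 1, `CSc1ccc(-c2nc3c(=O)n(C)c(=O)n(C)c3[nH]2)cc1`: in an assay for binding affinity to adenosine receptor A1 (Bos taurus) (a higher number here means a weaker inhibitor, a lower number a stronger inhibitor), compound 1 gives 2 nM.
Compound 2, `CCc1ccc(-c2nc3c(=O)n(C)c(=O)n(C)c3[nH]2)cc1`: in this assay compound 2 gives 0.8 nM.
Compound 3, `CCCCOc1ccc(-c2nc3c(=O)n(C)c(=O)n(C)c3[nH]2)cc1`: in this assay compound 3 gives 4 nM.

All three share one core and differ only in the group on the attached benzene ring. Compound 3 has the highest number of the three: a 2.0-fold higher number from compound 1 to compound 3 (0.30 log units; within the scatter), and a 5.0-fold higher number from compound 2 to compound 3 (0.70 log units; beyond the scatter). The unmeasured compound 4, `Cn1c(=O)c2nc(-c3ccc(F)cc3)[nH]c2n(C)c1=O`, keeps the core and changes that group: fluoro in place of butoxy on an aromatic carbon. Among the measured compounds shown here, two measured steps bear on this place. Swapping methylsulfanyl for ethyl gave a 2.5-fold lower number from compound 1 to compound 2 (0.40 log units; beyond the scatter), and swapping ethyl for butoxy gave a 5.0-fold higher number from compound 2 to compound 3 (0.70 log units; beyond the scatter); both are modest. Fluoro is far smaller than butoxy, and nothing among the measured compounds shows how small a group at this place behaves, so the expectation is uncertain and leans toward a somewhat weaker compound. Compound 4 is therefore expected to give 20 nM in this assay, within 5 nM to 80 nM, meaning an estimated 5.0-fold higher number from compound 3 to compound 4 (0.70 log units; beyond the scatter).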

Compound 4, half-maximal inhibitory concentration: 3.5 nM
Compound 4: the middle estimate sits 5.7-fold (0.76 log units) above what was measured; measured number below the stated range.
By their numbers in this assay, from the lowest: compound 2; then compounds 1, 4 and 3 (each within the scatter of the next).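

In this assay, the swap of a five-heavy-atom butoxy chain for a single fluoro gives a 1.1-fold lower number from compound 3 to compound 4 (0.06 log units; within the scatter) and so shows no measurable change at this place on the ring. Fluoro also cannot be told apart from methylsulfanyl, with a 1.8-fold higher number from compound 1 to compound 4 (0.24 log units; within the scatter) for that swap, whereas the change from ethyl gives a 4.4-fold higher number from compound 2 to compound 4 (0.64 log units; beyond the scatter) and keeps ethyl apart from the other three groups. Heavy-atom count alone therefore does not order these compounds, and ethyl, the group that stands apart, goes against any simple trend, but no supporting data are available to explain this result.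

The compounds shown leave open whether plain hydrogen, methyl or propyl at this place would give a number close to that of ethyl. They also leave open how an amine, a carboxylic acid or a chain longer than butoxy would behave here.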